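Working notes on compounds 1 to 4

The source may hold more compounds than are shown below. What is called first, only, known or untested is meant among the compounds shown, and "the series" means these compounds.

Compound 1 `O=C(Nc1ccc(OC(F)(F)F)cc1)NC1CCN(C(=O)c2ccoc2)CC1` stands second highest of the three numbers in a physicochemical assay for solubility, read by mass spectrometry, in phosphate buffer, with a stated time of 24 h, at pH 7.4 (a higher number here means a more soluble compound, a lower number a less soluble compound), giving 7.6 ug/mL. Compound 3 `CCC(=O)N1CCC(NC(=O)Nc2ccc(OC(F)(F)F)c(F)c2)CC1` gives 11 ug/mL, within the scatter of compound 1. Compound 2 `O=C(Nc1ccc(C(F)(F)F)cc1)NC1CCN(C(=O)c2ccoc2)CC1` gives 2.2 ug/mL; the step of a 3.5-fold lower number from compound 1 to compound 2 (0.54 log units; beyond the scatter) is beyond the scatter. Compound 4 `O=C(Nc1ccc(OC(F)(F)F)cc1)NC1CCN(C(=O)C2CCOC2)CC1` is not yet measured; it differs from compound 1 by oxolan-3-yl in place of furan-3-yl on a carbonyl carbon. Among the measured compounds shown here, none of the measured steps bears on this change: the one counted step, trifluoromethyl in place of trifluoromethoxy, lies on a different part of the shared core, so no measured step speaks for the ring on the carbonyl carbon. In this assay a modest rise is expected, a 2.0-fold higher number from compound 1 to compound 4 (0.30 log units; within the scatter), though not firmly beyond the scatter. The estimate for compound 4 is 15 ug/mL, between 5 ug/mL and 45 ug/mL.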

Compound 4, solubility: 29 ug/mL
The estimate for compound 4 lay 1.9-fold (0.29 log units) below the measured number; the range from low to high includes it.
By their numbers in this assay, from the lowest: compound 2; then compounds 1 and 3 (each within the scatter of the next); then compound 4.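

In this assay, the ring on the carbonyl carbon proves to be a position that moves the number: oxolan-3-yl in place of furan-3-yl gives a 3.8-fold higher number from compound 1 to compound 4 (0.58 log units; beyond the scatter) with the same count of heavy atoms, hydrogen-bond donors and acceptors. Among the compounds shown here, the change is from an aromatic to a non-aromatic five-membered ring, and it is the first measured step at this position. Nothing measured here accounts for the step.

Still open, on these data alone, is whether the same ring change holds with trifluoromethyl on the aromatic carbon, as in compound 2. Also open, as far as these compounds go, is what an amine or a longer chain on the carbonyl carbon would give in place of oxolan-3-yl.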